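Bromo in Place of Nitrile on the Core of Compound 1

This account rests on a few compounds, and the source may have more. Where it says the series, first, only, none or still open, it means among the compounds named here.

Compound 1, `N#Cc1ccccc1-c1nc2cccnc2o1`, gives the highest of the three numbers measured in a functional assay on the whole organism for inhibition, with Rattus norvegicus as the target, at a dose of 30 mg/kg; a higher number here means more inhibition at the dose given (going by the name of the read-out), a lower number less inhibition: compound 1 reaches 61%. Compound 2, `N#Cc1cccc(F)c1-c1nc2ncccc2o1`, comes nearest to it; in this assay compound 2 gives 50%, a number that sits beyond the scatter below compound 1. Compound 3, `Brc1cccc(-c2nc3ncccc3o2)c1`, lies furthest away: in this assay compound 3 gives 23%, again beyond the scatter below compound 1. No two of these measured compounds differ in a single place, so the three values stand side by side without a step between any pair.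

Compound 4, `Brc1ccccc1-c1nc2cccnc2o1`, has not yet been measured. It differs from compound 1 in one place: bromo in place of cyano on an aromatic carbon.

Among the measured compounds, the one bearing bromo is compound 3, and compound 3 in this assay gives 23%, the lowest of the three, though its core is not the core of compound 4. A downward step beyond the scatter is therefore expected, a number 26 percentage points lower from compound 1 to compound 4 (beyond the scatter), because compound 3 in this assay gives 23%. Compound 4 is expected to give about 35%, with a range from 10% to 60%.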

Compound 4, a percentage reported as inhibition, in the whole organism at one dose (the size of the read-out at that dose, not a potency): 31%
The estimate for compound 4 lay 4 percentage points above the measured number; the range from low to high includes it.
By their numbers in this assay, from the lowest: compounds 3 and 4 (each within the scatter of the next); then compound 2; then compound 1.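

With compound 4, the series gains its first step that changes one place alone: on an aromatic carbon of the six-membered ring of carbon only, ortho to a group of 9 heavy atoms, bromo in place of cyano gives a number 30 percentage points lower from compound 1 to compound 4 (beyond the scatter) in this assay. Among these compounds, on the core of compound 1, then, the nitrile at this place carries a real part of the inhibition seen at the dose given, and bromo does not keep it; the earlier compounds differ from one another in more than one place and could not isolate this single exchange. Nothing measured on these compounds speaks to what lies behind the loss.

The compounds shown leave open whether the loss is particular to bromo or would follow any departure from the nitrile, as a chlorine, a methoxy group or an amine at this same place could tell. They also leave open whether the same exchange would cost as much on the core of compound 2.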